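This account rests on a few compounds, and the source may have more. Where it says the series, first, only, none or still open, it means among the compounds named here.

Series notes. Compound 1 `COc1ccc2nc(C)cc(OCC(=O)Nc3ccccc3)c2c1` is the anilide of the shared core. In an ADME assay on HepG2 cells (Homo sapiens) for cytotoxicity, read by trypan blue exclusion, with a stated time of 48 h, in the presence of a further agent that is not named here (on this read-out higher numbers stand for lower toxicity in this test and lower numbers for higher toxicity in this test), compound 1 gives > 155000 nM, which is a limit of the assay and not a number. Compound 2 `COc1ccccc1NC(=O)COc1cc(C)nc2ccc(C(F)(F)F)cc12` in this assay gives > 128000 nM, again only a limit. Compound 3 `COc1ccc(NC(=O)COc2cc(C)nc3ccc(OC)cc23)c(OC)c1` in this assay gives > 131000 nM, also a limit. Within the data shown here, compound 1 therefore stands among values that are all limits, and no measured step can be drawn from them. Compound 4 `COc1ccc2nc(C)cc(OCC(=O)Nc3cccc(Br)c3)c2c1` differs from compound 1 by bromo in place of hydrogen on an aromatic carbon. Among the measured compounds shown here, with no measured step available, the expected step of an at least 1.0-fold lower number from compound 1 to compound 4 (0.01 log units; that floor lies within the scatter) is none beyond the scatter. For compound 4 the estimated value in this assay is 150000 nM, with an expected range from 60000 nM to 300000 nM, most likely reported again as a limit.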

Compound 4, half-maximal cytotoxic concentration: > 125000 nM
Compound 4: a limit, no number; the forecaster's own chance of this, stated with the estimate: 80%; the middle value does not contradict the limit.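

In this assay compound 1 and compound 4 both stand only as limits, so no step can be read between them. The compounds shown leave open whether bromo in place of hydrogen changes the half-maximal cytotoxic concentration at all.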